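Working notes on compound 3, predicted from compound 2

The compounds below may be only part of what the source reports. "The series", "measured", "known", "first", "only" and "open" are said of these compounds alone.

Within the data shown here, compound 2 `COc1ccc(OC)c(-c2cc(-c3ccccc3)nn2-c2ccc(S(=O)(=O)NC(C)=O)cc2)c1` carries the lowest of the two numbers so far in a functional assay on cells (Cancer cell lines, Homo sapiens) for cytotoxicity, read by sulforhodamine B assay, with a stated time of 48 h (on this read-out higher numbers stand for weaker inhibition of growth and lower numbers for stronger inhibition of growth), where compound 2 gives 18200 nM. Among the measured compounds shown here, its nearest neighbour is compound 1 `COc1ccc(OC)c(-c2cc(-c3ccccc3)nn2-c2ccc(S(N)(=O)=O)cc2)c1`, which in this assay gives 27500 nM; the only measured step, a 1.5-fold lower number from compound 1 to compound 2 (0.18 log units; within the scatter), changes nothing but the acetyl on the sulfonamide nitrogen and stays within the scatter.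

Compound 3 `CC(=O)NS(=O)(=O)c1ccc(-n2nc(-c3ccccc3)cc2C2=CC(=O)C=CC2=O)cc1` keeps the acetylated sulfonamide of compound 2 and changes the other end: a group of 8 heavy atoms (6 carbon, 2 oxygen; one six-membered non-aromatic ring of carbon only) in place of a group of 10 heavy atoms (8 carbon, 2 oxygen; one six-membered aromatic ring of carbon only), on an aromatic carbon. For the measured compounds named here, no measured step touches this position or exchanges an aromatic ring for a non-aromatic one, so the step from compound 1 to compound 2 does not bear on it and the direction of the change in this assay is not constrained by the data.

With nothing to anchor the step, the estimate for compound 3 is kept close to compound 2 and given a wide range; the expected step is a 1.2-fold lower number from compound 2 to compound 3 (0.08 log units; within the scatter). Compound 3 is therefore estimated at 15000 nM in this assay, with a range from 4000 nM to 50000 nM.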

Compound 3, concentration for total growth inhibition: 100000 nM
For compound 3 the middle estimate is 6.7-fold (0.82 log units) below the measured one; the measured number lies above the stated range.
By their numbers in this assay, from the lowest: compounds 2 and 1 (each within the scatter of the next); then compound 3.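

In this assay, the position on an aromatic carbon of the five-membered aromatic ring, next to the ring nitrogen, responds to the exchange of 2,5-dimethoxyphenyl for the group of 8 heavy atoms with its six-membered non-aromatic ring of carbon only: the result is a 5.5-fold higher number from compound 2 to compound 3 (0.74 log units; beyond the scatter), toward weaker inhibition of growth. Among these compounds, the only earlier step, a 1.5-fold lower number from compound 1 to compound 2 (0.18 log units; within the scatter), concerned the sulfonamide nitrogen and stayed within the scatter, so this is the first change to move the number beyond the scatter, and it shows that this position is not indifferent to what it carries. No measurement at hand accounts for the shift.

The pair cannot separate the loss of the aromatic ring from the loss of the two methoxy groups; an unsubstituted phenyl or a 2,5-dihydroxyphenyl at this position would address that question. Also open, going by these compounds, is whether the step holds with the free sulfonamide of compound 1 in place of the acetylated one, and how an amine or a carboxylic acid on the aromatic ring would read in this assay.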